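Opening a Ring: From Compound 2 Toward Compound 4

This account rests on a few compounds, and the source may have more. Where it says the series, first, only, none or still open, it means among the compounds named here.

Compound 2 `CC1CCCN(Cc2c(-c3nnc(SC(C)C)n3-c3ccccc3)n(C)c3ccc(F)cc23)C1` stands at the top of the three compounds measured in a physicochemical assay for lipophilicity (a lower number here means a more polar compound, a higher number a more lipophilic compound), where compound 2 gives 6.18. The nearest neighbour is compound 3 `CC(C)Sc1nnc(-c2c(CNCCN3CCCC3)c3ccccc3n2C)n1-c1ccccc1`, and in this assay compound 3 gives 4.83, a gap beyond the usual scatter. Furthest away is compound 1 `CC(C)Sc1nnc(-c2c(CNc3cnccn3)c3ccccc3n2C)n1-c1ccccc1`; in this assay compound 1 gives 4.22, also well beyond the scatter from compound 2.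

Among the measured compounds shown here, the only step measured so far swaps one group on an amine nitrogen of the shared core: a number 0.61 log units higher from compound 1 to compound 3 (beyond the scatter).

Compound 4 `COCCNCc1c(-c2nnc(SC(C)C)n2-c2ccccc2)n(C)c2ccc(F)cc12` is the next compound to be measured. It keeps the core of compound 2 and differs there in one place: (2-methoxyethyl)amino in place of 3-methylpiperidin-1-yl on a saturated chain carbon bound to an aromatic carbon. A ring of 6 carbon and 1 nitrogen leaves, and an open chain carrying 1 hydrogen-bond donor and 2 hydrogen-bond acceptors enters.

For the measured compounds named here, no measured step matches this change directly; the step from compound 1 to compound 3 alters the same region and was modest. The wide gap between compound 2 and compound 3 suggests that changes at this nitrogen can move the number a good deal. A step downward, well beyond the scatter, is therefore expected. The expected step is a number 1.28 log units lower from compound 2 to compound 4 (beyond the scatter). Compound 4 is expected to give about 4.9, with a likely range from 4.3 to 5.5.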

Compound 4, partition coefficient: 4.52
Compound 4: the middle estimate sits 0.38 log units above what was measured; the range from low to high includes it.
By their numbers in this assay, from the lowest: compounds 1 and 4 (each within the scatter of the next); then compound 3; then compound 2.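

In this assay, among the compounds shown here, putting (2-methoxyethyl)amino in place of 3-methylpiperidin-1-yl on a saturated chain carbon bound to an aromatic carbon gives a number 1.66 log units lower from compound 2 to compound 4 (beyond the scatter), the first measured step on the core of compound 2. For the compounds shown here, this large step shows that the group carried at this position can shift the number substantially, whereas the one earlier step, a number 0.61 log units higher from compound 1 to compound 3 (beyond the scatter), was modest, went the other way and involved a different exchange on a different core. No supporting measurement accompanies this result, so the data offer no explanation for the size of the step.

Because one exchange removes a ring and brings in an open chain with an oxygen and a donor hydrogen, the compounds shown cannot separate the contribution of each of these differences. Going by these compounds, whether an open chain without oxygen, such as butylamino, or a ring containing oxygen, such as morpholin-4-yl, would give a number closer to that of compound 2 or to that of compound 4 remains open.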